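The source may hold more compounds than are shown below. What is called first, only, known or untested is meant among the compounds shown, and "the series" means these compounds.

Measured compounds: compound 1 `Cc1ccccc1S(=O)(=O)Nc1ccc(-c2nc3ccccc3o2)cc1` with > 100000 nM; compound 2 `Cc1cccc(S(=O)(=O)Nc2ccc3oc(-c4ccccc4)nc3c2)c1` with 69000 nM.

In an ADME assay on HEK293 cells (Homo sapiens) for cytotoxicity, read by resazurin assay, with a stated time of 48 h (on this read-out lower numbers stand for higher toxicity in this test and higher numbers for lower toxicity in this test), compound 1 reaches only a limit, > 100000 nM, not a number. Going by the values given here, compound 2 gives 69000 nM in this assay, the single definite number in this set. The other value shown is the limit of > 100000 nM in this assay, at which 1 of the 2 values shown sits. Compound 3 `O=S(=O)(Nc1ccc2oc(-c3ccccc3)nc2c1)c1ccc(Cl)s1` differs from compound 2 by 5-chlorothiophen-2-yl in place of 3-methylphenyl on a sulfonyl sulfur. Among the compounds with values here, no measured pair carries this change, so the step of a 1.3-fold lower number from compound 2 to compound 3 (0.10 log units; within the scatter) is expected to stay within the usual scatter, in no clear direction. Compound 3 is estimated at 55000 nM in this assay, between 20000 nM and 100000 nM.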

Compound 3, half-maximal cytotoxic concentration: > 100000 nM
Compound 3 ended at the assay's limit; the forecaster's own chance of this, stated with the estimate: 30%; at least 1.8-fold (0.25 log units) between middle value and limit.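

In this assay, going by these compounds alone, placing 5-chlorothiophen-2-yl in place of 3-methylphenyl on a sulfonyl sulfur gives an at least 1.4-fold higher number from compound 2 to compound 3 (0.16 log units; that floor lies within the scatter), the first reading of any change at this position. That floor lies within the scatter, so no clear direction can be claimed, though a five-membered aromatic ring carrying chlorine can stand here with the read-out at the top of its range. Compound 3 gives only a limit, not a number, so the full size of the step stays unknown: the limit of > 100000 nM in this assay, at which 2 of the 3 values shown sit.

As far as these compounds go, how far compound 3 lies past that limit remains open. So does whether a chain bearing an amine or a carboxylic acid on this sulfonyl sulfur would give a definite number.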